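The source may hold more compounds than are shown below. What is called first, only, known or untested is meant among the compounds shown, and "the series" means these compounds.

Measured in a functional assay on MCF7 cells (Homo sapiens) for inhibition, read by CCK-8 assay, with a stated time of 48 h; on this read-out lower numbers stand for stronger inhibition and higher numbers for weaker inhibition:
- Compound 1 `COc1cc(-c2ccnc3cc(-c4cccc(C#N)c4)nn23)cc(OC)c1OC`: > 10000 nM, a limit of the assay and not a number.
- Compound 2 `COc1cc(-c2ccnc3cc(-c4ccccc4)nn23)cc(OC)c1OC`: 254 nM
- Compound 3 `COc1cc(-c2ccnc3cc(-c4ccc(C(F)(F)F)cc4)nn23)cc(OC)c1OC`: 2440 nM

Of the two actual numbers, compound 3 has the higher and compound 2 the lower. Compound 4 `COc1cc(-c2ccnc3cc(-c4ccc(C(C)=O)cc4)nn23)cc(OC)c1OC` carries acetyl in place of trifluoromethyl on an aromatic carbon, para to a large group (acetyl in place of trifluoromethyl on an aromatic carbon). The nearest evidence is the modest 9.6-fold higher number from compound 2 to compound 3 (0.98 log units; beyond the scatter), which adds trifluoromethyl in place of hydrogen. The large at least 39-fold lower number from compound 1 to compound 2 (1.59 log units; beyond the scatter) and the at least modest an at least 4.0-fold lower number from compound 1 to compound 3 (0.61 log units; beyond the scatter) show that the substituted phenyl can move the read-out considerably. Among the compounds with values here, no measured step exchanges one of these substituents directly for acetyl, so no clear direction is expected in this assay, and the expectation is for no step beyond the scatter. The estimated change is a 1.2-fold lower number from compound 3 to compound 4 (0.09 log units; within the scatter). Compound 4 is expected at 2000 nM, with an estimated range of 500 nM to 8000 nM.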

Compound 4, half-maximal inhibitory concentration: 5230 nM
Compound 4: the middle estimate sits 2.6-fold (0.42 log units) below what was measured; measured number inside the range.
By their numbers in this assay, from the lowest: compound 2; then compound 3; then compound 4. At a limit, above all of these: compound 1.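

In this assay, acetyl in place of trifluoromethyl gives a 2.1-fold higher number from compound 3 to compound 4 (0.33 log units; beyond the scatter), a modest step towards weaker inhibition, so this position separates these two substituents. Acetyl in place of hydrogen gives a 21-fold higher number from compound 2 to compound 4 (1.31 log units; beyond the scatter), and both substituted compounds, compound 3 and compound 4, therefore stand above compound 2, with acetyl the larger rise. The step of an at least 1.9-fold lower number from compound 1 to compound 4 (0.28 log units; that floor lies within the scatter) rests on a limit and sets no order between the two. Compound 1 stands at that limit, which is not a number: the limit of > 10000 nM in this assay, at which 1 of the 4 values shown sits.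

On these data alone, whether any substituent here can bring the number below that of compound 2 remains open. So does whether an amine, a hydroxyl or a carboxylic acid at this position would follow acetyl or trifluoromethyl.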